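The source may hold more compounds than are shown below. What is called first, only, known or untested is meant among the compounds shown, and "the series" means these compounds.

Compound 1 `Cn1c(-c2ccc(NC(=O)CCl)cc2)nc(-c2ccccc2)c1-c1ccccc1` and compound 2 `CCN1CCN(CC(=O)Nc2ccc(-c3nc(-c4ccccc4)c(-c4ccccc4)n3C)cc2)CC1` share one core and differ at a single place. In a functional assay on MCF7 cells (Homo sapiens) for cytotoxicity, read by MTT assay, with a stated time of 24 h, tested at 80 ug/mL (a higher number here means a stronger effect of the compound at the concentration tested, a lower number a weaker effect), compound 1 gives 70%, and compound 2 gives 46.3%, the lowest of the two numbers shown; the step of a number 23.7 percentage points lower from compound 1 to compound 2 (beyond the scatter) separates them. Compound 3 `Cn1c(-c2ccc(NC(=O)CN3CCN(c4ccccc4)CC3)cc2)nc(-c2ccccc2)c1-c1ccccc1` has not yet been measured. It differs from compound 2 by phenyl in place of ethyl on an amine nitrogen in a ring. Going by the values given here, no measured step touches that place: the only step known, a number 23.7 percentage points lower from compound 1 to compound 2 (beyond the scatter), set the whole 4-ethylpiperazin-1-yl group in place of chloro rather than altering a group already held by the ring nitrogen, so it offers no direct guidance on the size or direction of the present change. With nothing in the data pointing either way, the expected step in this assay is a number 3.7 percentage points higher from compound 2 to compound 3 (within the scatter), within the scatter. Compound 3 is accordingly estimated at 50%, with a range from 30% to 70%.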

Compound 3, a percentage reported as activity, at one concentration (the size of the read-out at that concentration, not a potency): 72.5%
The estimate for compound 3 lay 22.5 percentage points below the measured number; the whole stated range lies below it.
By their numbers in this assay, from the lowest: compound 2; then compounds 1 and 3 (each within the scatter of the next).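

In this assay, the group on the amine nitrogen in the ring proves to matter in its own right, a point the earlier pair could not show since it only exchanged the whole 4-ethylpiperazin-1-yl group for chloro: a number 26.2 percentage points higher from compound 2 to compound 3 (beyond the scatter). The loss seen on going from chloro to 4-ethylpiperazin-1-yl therefore does not extend to every group of this kind, for 4-phenylpiperazin-1-yl gives a number 2.5 percentage points higher from compound 1 to compound 3 (within the scatter). No supporting measurement is available to explain this difference between ethyl and phenyl.

The compounds shown leave open whether the step goes with the aromatic ring or simply with the larger carbon group, which a cyclohexyl or a benzyl group on that nitrogen would help to separate. They also leave open how a substituent on the phenyl ring, such as a fluorine or a methoxy group, would read.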